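This account rests on a few compounds, and the source may have more. Where it says the series, first, only, none or still open, it means among the compounds named here.

In an in vitro assay on BaF3 cells for displacement of a labelled ligand from C-X-C chemokine receptor type 3 (Homo sapiens) (a lower number here means a stronger inhibitor, a higher number a weaker inhibitor), three compounds have been measured so far. Compound 1, `CC[C@H]1CN(c2ncc(C(N)=O)nc2Cl)CCN1C1CCN(C(=O)c2ccc(Cl)nc2N)CC1`, gives 2.5 nM. Compound 2, `CC[C@H]1CN(c2ncc(C(=O)NC3CC3)nc2Cl)CCN1C1CCN(C(=O)c2ccc(Cl)nc2N)CC1`, gives 1.2 nM. Compound 3, `CC[C@H]1CN(c2ncc(C(N)=O)nc2C)[C@H](C)CN1C1CCN(C(=O)c2ccc(Cl)cc2)CC1`, gives 5.4 nM, the highest of the three numbers.

Compound 1 and compound 2 differ in a single place: cyclopropyl in place of hydrogen on an amide-type nitrogen. That change produced a 2.1-fold lower number from compound 1 to compound 2 (0.32 log units; beyond the scatter). Compound 3 carries the same carbamoyl end as compound 1 but differs from it in more than one place; the difference between the two cores is not broken down here.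

Compound 4, `CC[C@H]1CN(c2ncc(C(=O)NC3CC3)nc2C)[C@H](C)CN1C1CCN(C(=O)c2ccc(Cl)cc2)CC1`, has not yet been measured in this assay. It stands to compound 3 exactly as compound 2 stands to compound 1: cyclopropyl in place of hydrogen on an amide-type nitrogen, the same change at the same kind of place, an amide-type nitrogen whose other neighbour is a carbonyl carbon.

Compound 4 is therefore expected to show a 2.1-fold lower number from compound 3 to compound 4 (0.32 log units; beyond the scatter). That expectation rests on a single precedent, a 2.1-fold lower number from compound 1 to compound 2 (0.32 log units; beyond the scatter), and on nothing else. For compound 4 the estimated value is 2.6 nM, with a likely range from 1.2 nM to 5.5 nM.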

Compound 4, half-maximal inhibitory concentration: 1.3 nM
Beside the measured number, compound 4's estimate is 2.0-fold (0.30 log units) above it, within the range that was stated.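

In this assay, putting cyclopropyl in place of the amide hydrogen again lowered the number, giving a 4.2-fold lower number from compound 3 to compound 4 (0.62 log units; beyond the scatter). Compared with the earlier step, the result on the second core agrees with the first within normal measurement scatter, so in this small set the change carried from one core to the other with a gain of similar size: the same change on two cores in this assay, a 2.1-fold lower number (0.32 log units; beyond the scatter) from compound 1 to compound 2 and a 4.2-fold lower number (0.62 log units; beyond the scatter) from compound 3 to compound 4, 2.0-fold (0.30 log units) apart, within the scatter of two such steps. For the compounds shown here, this rests on only one pair of compounds on each of two cores, so it does not show that the change would carry to any further core, and it does not explain why the number falls.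

The compounds shown leave open whether other groups on that amide nitrogen, such as methyl, cyclobutyl or a longer chain like n-butyl, would match cyclopropyl. They also leave open what a carboxylic acid or a nitrile would do in place of the whole carbamoyl end on either core.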